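One Stereocentre Flipped in a Cytotoxic Compound

The source may report more compounds than this note shows. Statements on the series, on what has been measured and on what is new or still open speak of the compounds shown alone.

Going by the values given here, in a functional assay on A549 cells (Homo sapiens) for cytotoxicity (on this read-out higher numbers stand for weaker inhibition and lower numbers for stronger inhibition), compound 2 (`CCCCCCCCCCCCCC[C@H]1N[C@@H](CO)[C@@H]1O`) gives 0.22 ug/mL, the only exact number so far. Compound 1 (`CCCCCCCCCCCCCC[C@H]1N[C@H](CO)[C@H]1O`) gives only a limit, > 2 ug/mL. Among the compounds with values here, the single measured step is an at least 9.0-fold lower number from compound 1 to compound 2 (0.95 log units; beyond the scatter). Its size rests on (the limit of > 2 ug/mL in this assay, at which 1 of the 2 values shown sits), and the gap comes with the fact that compounds 1 and 2 differ only in the configuration as drawn, so spatial arrangement alone separates these two compounds.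

Compound 3 (`CCCCCCCCCCCCCC[C@H]1N[C@@H](CO)[C@H]1O`) is a further stereoisomer: the two compounds have the same atoms and bonds and differ only in configuration as drawn: 1 of 3 stereo elements differ; a stereocentre at a saturated ring carbon is drawn R in compound 2 and S in compound 3. This reverses only one stereocentre, whereas the measured step involved two. Within the data shown here, that step is the only guide, and it cannot show how much each stereocentre contributes. Starting from compound 2 at 0.22 ug/mL, and given an at least 9.0-fold lower number from compound 1 to compound 2 (0.95 log units; beyond the scatter), a move towards weaker inhibition seems likely, though probably a smaller one than the measured step. The expected change is a 3.2-fold higher number from compound 2 to compound 3 (0.50 log units; beyond the scatter) in this assay. For compound 3 the estimated value is 0.7 ug/mL, with an expected range from 0.15 ug/mL to 3 ug/mL.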

Compound 3, half-maximal inhibitory concentration: 1.38 ug/mL
For compound 3 the middle estimate is 2.0-fold (0.29 log units) below the measured one; low and high end bracket the measured number.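

Reversing a single ring stereocentre is already enough in this assay, with a 6.3-fold higher number from compound 2 to compound 3 (0.80 log units; beyond the scatter), so one position carries a clear share of a gap that could earlier be assigned only to two stereocentres together; nothing but the spatial arrangement changes in this step: the fact that compounds 2 and 3 differ only in the configuration as drawn. The other stereocentre, reversed on its own, gives an at least 1.4-fold lower number from compound 1 to compound 3 (0.16 log units; that floor lies within the scatter), and this floor lies within the scatter, so it does not show that this second reversal matters. Compound 1 gives only a limit, > 2 ug/mL, and the true size of this second step therefore cannot be read: the limit of > 2 ug/mL in this assay, at which 1 of the 3 values shown sits.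

As far as these compounds go, the third stereocentre is drawn alike in all three compounds, so its contribution remains unknown, and the same is true of the stereoisomers in which it is reversed. Going by these compounds alone, also open is whether the same dependence on configuration would hold with an amine in place of the hydroxyl group, or with a longer chain in place of the one shared by these compounds.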